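This account rests on a few compounds, and the source may have more. Where it says the series, first, only, none or still open, it means among the compounds named here.

In an ADME assay on MT4 cells (Homo sapiens) for cytotoxicity, read by MTT assay (a lower number here means that less compound is tolerated, a higher number that more compound is tolerated), compound 3 `CCc1c(Cc2c(Cl)cccc2Cl)nc(SCC(=O)c2ccccc2)[nH]c1=O` gives only a limit and not a number, > 52000 nM. Compound 2 `Cc1c(Cc2c(Cl)cccc2Cl)nc(SCC(=O)c2ccccc2)[nH]c1=O` also gives a limit, > 60000 nM. Compound 1 `COc1ccc(C(=O)CSc2nc(Cc3c(Cl)cccc3Cl)cc(=O)[nH]2)cc1` gives a limit too, > 11000 nM. None of the three results is therefore an exact number, and compound 3 cannot be ranked precisely against the others.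

Compound 4 `CCc1c(Cc2c(Cl)cccc2Cl)nc(SCC(=O)c2ccc(OC)cc2)[nH]c1=O` differs from compound 3 by one change: methoxy in place of hydrogen on an aromatic carbon. This is methoxy in place of hydrogen on an aromatic carbon, para to a large group, which turns phenyl into 4-methoxyphenyl.

For the measured compounds named here, the one measured step, a step that the two limits leave unreadable from compound 2 to compound 3, is a different change, methyl in place of hydrogen on a saturated chain carbon bound to an aromatic carbon, and it offers no size to carry over. Compound 1 already carries the 4-methoxyphenyl group, yet it too gives only a limit, so it shows no readable effect of the methoxy. With no measured size to build on, no step beyond the usual scatter is expected in this assay, and the estimated step is an at least 1.3-fold lower number from compound 3 to compound 4 (0.11 log units; that floor lies within the scatter). Another limit is also the likeliest kind of result. For compound 4 the expected value is 40000 nM, with an estimated range from 12000 nM to 90000 nM.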

Compound 4, half-maximal cytotoxic concentration: > 54000 nM
Compound 4 ended at the assay's limit; the forecaster's own chance of this, stated with the estimate: 75%; middle value at least 1.3-fold (0.13 log units) away from the limit.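

Compound 4 gives only a limit, as do compound 3 and compound 1, so neither the step from compound 3 to compound 4 nor the step from compound 1 to compound 4 can be read in this assay. The compounds shown leave open whether the methoxy or the ethyl group changes the concentration that cells tolerate.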